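Ethylsulfonylpropyl chain in place of methylsulfonylphenoxy

A few compounds are considered here, and "the series" means these few. Any claim that something is new, unique, unknown or untested is made for them only; others in the source may bear on it.

Measured so far:
Compound 1 `Cn1c(-c2ccccc2C(F)(F)F)nnc1C12CCC(COc3ccc(S(C)(=O)=O)cc3)(CC1)CC2`: > 4000 nM, a limit of the assay.
Compound 2 `CCS(=O)(=O)CCC12CCC(c3nnc(-c4ccccc4Br)n3C)(CC1)CC2`: > 4000 nM, a limit of the assay.
Compound 3 `CCS(=O)(=O)CCC12CCC(c3nnc(-c4ccccc4C)n3C)(CC1)CC2`: > 4000 nM, a limit of the assay.

All three values come from an assay on CHO-K1 cells for inhibition of 11-beta-hydroxysteroid dehydrogenase type 2 (Homo sapiens), read by scintillation proximity assay; on this read-out lower numbers stand for stronger inhibition and higher numbers for weaker inhibition. Compound 1 stands only at a limit there, and no number can be given for it. Compound 2 and compound 3 sit at the same limit, so every value shown rests at the limit of > 4000 nM in this assay, at which 3 of the 3 values shown sit. Among the measured compounds shown here, the single step between measured compounds, a step that the two limits leave unreadable from compound 2 to compound 3, cannot be read for size or direction, and it concerns the aromatic substituent rather than the chain on the saturated carbon.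

Compound 4 `CCS(=O)(=O)CCCCC12CCC(c3nnc(-c4ccccc4C(F)(F)F)n3C)(CC1)CC2` differs from compound 1 by 3-(ethylsulfonyl)propyl in place of 4-(methylsulfonyl)phenoxy on a saturated chain carbon bound to a saturated ring carbon. For the measured compounds named here, no measured step covers this change. Compound 2 and compound 3 carry a related ethylsulfonyl chain at that position and both stand at the limit, which gives no readable size for any step in this assay.

Compound 4 is therefore expected to stay at the limit as well, with an estimate of 8000 nM in the range 2000 nM to 40000 nM. The step from compound 1 that this estimate implies, a step that the limit leaves unreadable from compound 1 to compound 4, is expected to lie within the scatter, with no gain in inhibition read from the data shown.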

Compound 4, half-maximal inhibitory concentration: > 4000 nM
Compound 4: a limit, no number; the forecaster's own chance of this, stated with the estimate: 80%; the middle value is on the limit's open side.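

Among the compounds shown here, compound 1 and compound 4 both stand at a limit of the assay, so no step between them can be read for size or direction. The compounds shown leave open whether any change to the chain or the aromatic substituent alters inhibition, with all values resting at one limit: the limit of > 4000 nM in this assay, at which 4 of the 4 values shown sit.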